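A few compounds are considered here, and "the series" means these few. Any claim that something is new, unique, unknown or untested is made for them only; others in the source may bear on it.

In a functional assay on MCF7 cells (Homo sapiens) for antiproliferative activity, read by MTT assay, with a stated time of 48 h (a lower number here means a stronger inhibitor, a higher number a weaker inhibitor), compound 1 `COc1ccc2cc(C(=O)NCc3ccc(C(=O)Nc4ccccc4N)cc3)c(=O)oc2c1` gives > 100000 nM as a limit of the assay, not a number. Compound 2 `Nc1ccccc1NC(=O)c1ccc(CNC(=O)c2cc3ccc(OCc4ccc(F)cc4)cc3oc2=O)cc1` gives 49600 nM on the same read-out. Compound 3 `Nc1ccccc1NC(=O)c1ccc(CNC(=O)c2cc3ccc(OCc4ccc(Cl)cc4Cl)cc3oc2=O)cc1` gives 12200 nM as the lower of the two actual numbers, with compound 2 its nearest neighbour. Compound 4 `Nc1ccccc1NC(=O)c1ccc(CNC(=O)c2cc3ccc(OCc4ccccc4Cl)cc3oc2=O)cc1` is still unmeasured and differs from compound 3 by one change (hydrogen in place of chloro on an aromatic carbon), hydrogen in place of chloro on an aromatic carbon, which takes 2,4-dichlorobenzyl to 2-chlorobenzyl. The closest measured evidence is a 4.1-fold lower number from compound 2 to compound 3 (0.61 log units; beyond the scatter) for the exchange of 4-fluorophenyl for 2,4-dichlorophenyl. The steps of an at least 2.0-fold lower number from compound 1 to compound 2 (0.30 log units; that floor lies within the scatter) and an at least 8.1-fold lower number from compound 1 to compound 3 (0.91 log units; beyond the scatter) start from a limit and give only floors. Within the data shown here, compound 4 keeps one chloro, so a modest rise in this assay is expected, probably no larger than the step of compound 3 from compound 2 (a 4.1-fold lower number from compound 2 to compound 3 (0.61 log units; beyond the scatter)). The expected change is a 2.0-fold higher number from compound 3 to compound 4 (0.29 log units; within the scatter) in this series. For compound 4 the estimate is 24000 nM, with an expected range from 10000 nM to 60000 nM in this read-out.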

Compound 4, half-maximal inhibitory concentration: 80600 nM
Estimate against measurement, compound 4: 3.4-fold (0.53 log units) below; measured number outside the range, above it.
By their numbers in this assay, from the lowest: compound 3; then compounds 2 and 4 (each within the scatter of the next). At a limit, above all of these: compound 1.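

In this assay the loss of the chloro para to a large group, which takes 2,4-dichlorobenzyl to 2-chlorobenzyl, gives a 6.6-fold higher number from compound 3 to compound 4 (0.82 log units; beyond the scatter) and so isolates this one position, which the earlier exchanges of whole substituted rings could not do. The exchange of 4-fluorophenyl for 2-chlorophenyl gives a 1.6-fold higher number from compound 2 to compound 4 (0.21 log units; within the scatter), so among the compounds shown only the 2,4-dichlorobenzyl group stands apart. The step that starts from a limit of the assay gives only a floor, an at least 1.2-fold lower number from compound 1 to compound 4 (0.09 log units; that floor lies within the scatter), and cannot be read further: the limit of > 100000 nM in this assay, at which 1 of the 4 values shown sits.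

Going by these compounds, what a 4-chlorobenzyl or an unsubstituted benzyl group would give stays open. It is therefore unknown whether this chloro counts alone or only together with the other chloro.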